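The compounds below may be only part of what the source reports. "The series", "measured", "known", "first", "only" and "open" are said of these compounds alone.

Measured so far in a functional assay on A549 cells (Homo sapiens), read by MTT assay, with a stated time of 72 h; a lower number here means a stronger inhibitor, a higher number a weaker inhibitor:
- compound 1 `Nc1nc2c(c(-c3ccco3)cn2[C@@H]2O[C@H](CO)[C@@H](O)[C@H]2O)c(=O)[nH]1`: > 20000 nM, a limit and not a number
- compound 2 `Nc1nc2c(c(-c3cccs3)cn2[C@@H]2O[C@H](CO)[C@@H](O)[C@H]2O)c(=O)[nH]1`: > 20000 nM, a limit and not a number

Compound 2 therefore has no exact position on the scale, only its limit. It shares that position with compound 1, as the evidence shows: the limit of > 20000 nM in this assay, at which 2 of the 2 values shown sit. Going by the values given here, the one measured step is a step that the two limits leave unreadable from compound 1 to compound 2, with thiophen-2-yl in place of furan-2-yl on an aromatic carbon, so it offers no size to carry forward.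

Compound 3 `Nc1nc2c(c(-c3ccsc3)cn2[C@@H]2O[C@H](CO)[C@@H](O)[C@H]2O)c(=O)[nH]1` has thiophen-3-yl in place of thiophen-2-yl on an aromatic carbon. The two compounds have the same atoms, joined differently. With no readable step to suggest a direction, no change beyond the scatter is expected in this assay, and another limit is the likeliest result. The expected step is a step that the limit leaves unreadable from compound 2 to compound 3. For compound 3 the estimated value is 28000 nM, with an expected range from 10000 nM to 80000 nM.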

Compound 3, half-maximal inhibitory concentration: > 20000 nM
Compound 3 gave a limit, no number; the forecaster's own chance of this, stated with the estimate: 85%; the middle value is on the limit's open side.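

The steps among compound 1, compound 2 and compound 3 cannot be read, since in this assay each gave a limit and not a number: the limit of > 20000 nM in this assay, at which 3 of the 3 values shown sit.

The compounds shown leave open how strong each one really is, and whether furan-2-yl, thiophen-2-yl and thiophen-3-yl differ at all in their effect.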